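Compound 2 to compound 3: aryl change on the sulfonamide

This account rests on a few compounds, and the source may have more. Where it says the series, first, only, none or still open, it means among the compounds named here.

For the measured compounds named here, compound 2 (`O=C1NCCN1c1ccc(S(=O)(=O)Nc2cccc(Br)c2)cc1`) gives 59 nM in a functional assay on M21 cells (Homo sapiens) for antiproliferative activity, read by sulforhodamine B assay, with a stated time of 48 h (on this read-out higher numbers stand for weaker inhibition and lower numbers for stronger inhibition), and stands lowest of the two numbers so far, with compound 1 (`Cc1ccc(NS(=O)(=O)c2ccc(N3CCNC3=O)cc2)cc1`) at 260 nM as the other. Compound 3 (`O=C1NCCN1c1ccc(S(=O)(=O)Nc2ccc(Cl)cc2)cc1`) carries 4-chlorophenyl in place of 3-bromophenyl on a sulfonamide nitrogen. Going by the values given here, only one measured step bears on this place, a modest one that starts from the 4-methylphenyl of compound 1 (a 4.4-fold lower number from compound 1 to compound 2 (0.64 log units; beyond the scatter)). A smaller move back toward compound 1 is therefore expected in this assay, to a higher number and probably beyond the scatter. The expected step is a 2.9-fold higher number from compound 2 to compound 3 (0.46 log units; beyond the scatter) in size. For compound 3 the estimated value is 170 nM (range 55 nM to 520 nM).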

Compound 3, half-maximal inhibitory concentration: 90 nM
Compound 3: the middle estimate sits 1.9-fold (0.28 log units) above what was measured; the measured number falls inside the stated range.
By their numbers in this assay, from the lowest: compounds 2 and 3 (each within the scatter of the next); then compound 1.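

In this assay, 4-chlorophenyl in place of 3-bromophenyl on the sulfonamide nitrogen gives no readable change (a 1.5-fold higher number from compound 2 to compound 3 (0.18 log units; within the scatter)). Chloro in place of methyl on an aromatic carbon does register (a 2.9-fold lower number from compound 1 to compound 3 (0.46 log units; beyond the scatter)), so both halogen-bearing aryl groups stand below the 4-methylphenyl of compound 1, and none of the three compounds goes against this. No measurement on hand accounts for these differences.

Halogen identity and halogen place change together between compound 2 and compound 3, so their separate contributions remain unresolved. From the compounds shown here alone, whether an amine or a carboxylic acid on this aryl ring would be tolerated also stays open.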